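This account rests on a few compounds, and the source may have more. Where it says the series, first, only, none or still open, it means among the compounds named here.

Working notes on the shared core. Compound 1 `COc1cc(Cn2cc(COc3cccc(/C=C4/C(=O)Nc5ccccc54)c3)nn2)cc(OC)c1`, carrying the 3,5-dimethoxybenzyl group on the triazole and no substituent on the fused ring, gives 37100 nM in a functional assay on PC-3 cells (Homo sapiens) for inhibition, read by MTT assay, with a stated time of 48 h; on this read-out higher numbers stand for weaker inhibition and lower numbers for stronger inhibition. Compound 2 `O=C1Nc2ccc(Br)cc2/C1=C/c1cccc(OCc2cn(Cc3ccccc3)nn2)c1` returns only > 50000 nM in this assay, which is a limit of the measurement and not a number. As far as these compounds go, compound 2 therefore stands at the limit of > 50000 nM in this assay, at which 1 of the 2 values shown sits, and where it lies beyond that boundary is unknown.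

Compound 3 `COc1ccc(Cc2ccc3c(c2)/C(=C/c2cccc(OCc4cn(Cc5ccccc5)nn4)c2)C(=O)N3)cc1` differs from compound 2 in one place: 4-methoxybenzyl in place of bromo on an aromatic carbon. Going by the values given here, no measured pair covers this exchange, so there is no measured step to set its size. Both measured values sit at weak inhibition, and a move much beyond the scatter is not anticipated. Compound 3 is estimated at 40000 nM in this assay, within a range of 15000 nM to 100000 nM. The step of an at least 1.2-fold lower number from compound 2 to compound 3 (0.09 log units; that floor lies within the scatter) is expected to be small, possibly toward somewhat stronger inhibition but not clearly beyond the scatter.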

Compound 3, half-maximal inhibitory concentration: > 50000 nM
Compound 3: a limit, no number (the forecaster's own chance of this, stated with the estimate: 45%); middle value at least 1.2-fold (0.09 log units) from the limit.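

Compound 3 gives > 50000 nM in this assay as a limit and not a number. Going by these compounds alone, with compound 2 also at a limit, no step between compound 2 and compound 3 can be read. Open remains whether exchanging bromo for 4-methoxybenzyl changes inhibition at all.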